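Dialkylamino in place of arylamino at the enaminone carbon

The source may report more compounds than this note shows. Statements on the series, on what has been measured and on what is new or still open speak of the compounds shown alone.

Compound 1 `Cc1ccc(NC2=CC(=O)c3c(nc4n3[C@H]3OC[C@@H](O)[C@H]3OC4)C2=O)cc1C`: 1050 nM in a functional assay on MGC-803 cells (Homo sapiens) for inhibition, read by sulforhodamine B assay; on this read-out higher numbers stand for weaker inhibition and lower numbers for stronger inhibition
Compound 2 `COc1ccc(NC2=CC(=O)c3nc4n(c3C2=O)[C@H]2OC[C@@H](O)[C@H]2OC4)cc1`: 1680 nM
Compound 3 `O=C1C=C(N2CCCCC2)C(=O)c2c1nc1n2[C@H]2OC[C@@H](O)[C@H]2OC1`: > 8000 nM, a limit of the assay

On the numbers shown, compound 1 and compound 2 lie within the scatter of each other; the value of compound 3 is a limit. Going by the values given here, the only measured step at this position is an at least 4.7-fold higher number from compound 2 to compound 3 (0.67 log units; beyond the scatter), an arylamine exchanged for a cyclic dialkylamine. Compound 3 sits at the limit of > 8000 nM in this assay, at which 1 of the 3 values shown sits.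

Compound 4 `CCCN(CCC)C1=CC(=O)c2c(nc3n2[C@H]2OC[C@@H](O)[C@H]2OC3)C1=O` carries the change (dipropylamino in place of (3,4-dimethylphenyl)amino on a double-bonded ring carbon). This is again an arylamine given up for a dialkylamine on the same double-bonded ring carbon, so a weakening of comparable size is expected in this assay, a 5.7-fold higher number from compound 1 to compound 4 (0.76 log units; beyond the scatter). Compound 4 is therefore estimated at 6000 nM, between 2500 nM and 15000 nM, with a fair chance that only a limit is reported.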

Compound 4, half-maximal inhibitory concentration: > 16000 nM
Compound 4: a limit, no number; the forecaster's own chance of this, stated with the estimate: 45%; at least 2.6-fold (0.42 log units) between middle value and limit.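

With dipropylamino, a chain without a ring, the exchange of arylamine for dialkylamine again weakens inhibition in this assay, with an at least 15-fold higher number from compound 1 to compound 4 (1.18 log units; beyond the scatter). The loss on this double-bonded ring carbon therefore holds for both a cyclic and an open-chain dialkylamine, in compound 3 and compound 4, and neither goes against it. The value of compound 4 is a limit and not a number: the limit of > 16000 nM in this assay, at which 1 of the 4 values shown sits.

The two limits cannot be ordered against each other. Nor do the compounds shown separate loss of the aromatic ring from loss of the amine hydrogen, which a cyclohexylamino group on the same carbon could address.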